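The source may hold more compounds than are shown below. What is called first, only, known or untested is meant among the compounds shown, and "the series" means these compounds.

In a functional assay on the whole organism for antagonist activity, with Mus musculus as the target, in the maximal electroshock model (on this read-out higher numbers stand for an effect only at larger amounts of compound and lower numbers for an effect already at smaller amounts), compound 1 (`COC(=O)NC1=NC(c2ccccc2)CN1C`) gives 107 mg/kg and compound 2 (`CC(C)COC(=O)NC1=NC(c2ccccc2)CN1C`) gives 70 mg/kg on the same read-out. For the measured compounds named here, the only measured step is a 1.5-fold lower number from compound 1 to compound 2 (0.18 log units; within the scatter) and so compound 1 cannot be set apart from compound 2 on these numbers. Compound 3 (`CCN1CC(c2ccccc2)N=C1NC(=O)OC`) has not yet been measured. It departs from compound 1 by methyl in place of hydrogen on a saturated chain carbon bound to an amine nitrogen in a ring in a single place, which amounts to methyl to ethyl. Going by the values given here, the measured step lies at a different place, on a saturated chain carbon bound to an oxygen next to a carbonyl group, and the data hold no step at the new one. It therefore bears only indirectly, and no shift beyond the scatter is expected in this assay. The expected step is a 1.1-fold lower number from compound 1 to compound 3 (0.05 log units; within the scatter) and it has no firm direction. For compound 3 the estimated value is 95 mg/kg with an expected range of 45 mg/kg to 200 mg/kg for this estimate.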

Compound 3, dose for half-maximal effect: 66 mg/kg
Compound 3: the middle estimate sits 1.4-fold (0.16 log units) above what was measured; the measured number falls inside the stated range.
By their numbers in this assay, from the lowest: compounds 3, 2 and 1 (each within the scatter of the next).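

In this assay, methyl in place of hydrogen on a saturated chain carbon bound to an amine nitrogen in a ring gives a 1.6-fold lower number from compound 1 to compound 3 (0.21 log units; within the scatter). For the compounds shown here, this is the first reading at this place, and it shows that methyl to ethyl there stays within the usual scatter of the assay, so the data do not set the two compounds apart. No independent measurement is available to interpret this step.

The compounds shown leave open whether a longer chain, a benzyl group or a carboxylic acid at this place would give a step beyond the scatter. They also leave open how the ethyl group would read together with the isopropyl change of a 1.5-fold lower number from compound 1 to compound 2 (0.18 log units; within the scatter) in a single compound.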